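From chloro to fluoro: compound 2 and compound 3

This account rests on a few compounds, and the source may have more. Where it says the series, first, only, none or still open, it means among the compounds named here.

Values in a functional assay on the whole organism for antagonist activity, with Mus musculus as the target, in the maximal electroshock model (a higher number here means that more compound is needed for the effect, a lower number that less compound is needed), so far
compound 1 `CSc1nnc(-c2cccc3ccccc23)n1C` gives > 200 mg/kg
compound 2 `CSc1nnc(-c2ccccc2Cl)n1C` gives > 50 mg/kg

Neither entry is a number, as both are limits of the assay. Compound 2 stands only at the limit of > 50 mg/kg in this assay and has no exact value. Compound 1 likewise gives only a limit, > 200 mg/kg in this series. For the measured compounds named here, no measured step therefore shows how a change on the shared core acts.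

Compound 3 `CSc1nnc(-c2ccccc2F)n1C` has fluoro in place of chloro on an aromatic carbon, ortho to a group of 8 heavy atoms fluoro in place of chloro on an aromatic carbon and is otherwise the same as compound 2. With only the limit of compound 2 to go on, the expected step of an at least 1.1-fold lower number from compound 2 to compound 3 (0.04 log units; that floor lies within the scatter) is estimated to stay within the usual scatter, with no direction favoured. For compound 3 the expected value is 45 mg/kg in this assay and the estimated range runs from 15 mg/kg to 150 mg/kg.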

Compound 3, dose for half-maximal effect: > 200 mg/kg
Compound 3 gave a limit, no number (the forecaster's own chance of this, stated with the estimate: 40%); middle value at least 4.4-fold (0.64 log units) from the limit.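

In this assay, no step can be read between compound 2 and compound 3: each gives only a limit, not a number. On these data alone, whether fluoro in place of chloro changes the dose needed stays open, as does the exact dose for compound 1, compound 2 and compound 3.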